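Swapping the aryl group on the triazole nitrogen

The compounds below may be only part of what the source reports. "The series", "measured", "known", "first", "only" and "open" are said of these compounds alone.

Measured compounds:
- compound 1, `Cc1ccc(-n2cc(-c3ccccc3NS(=O)(=O)c3c[nH]c(=O)[nH]c3=O)nn2)cc1`: 2190 nM
- compound 2, `O=c1[nH]cc(S(=O)(=O)Nc2ccccc2-c2cn(-c3ccccc3F)nn2)c(=O)[nH]1`: 15300 nM
- compound 3, `O=c1[nH]cc(S(=O)(=O)Nc2ccccc2-c2cn(-c3cccc(F)c3)nn2)c(=O)[nH]1`: > 20000 nM

Three compounds share one core and differ only in the aryl group on the aromatic nitrogen. In a functional assay on OVCAR-3 cells (Homo sapiens) for antiproliferative activity, read by MTT assay, with a stated time of 24 h (a lower number here means a stronger inhibitor, a higher number a weaker inhibitor), compound 1 gives 2190 nM. Compound 2 gives 15300 nM in this assay. For compound 3 this assay reports only a limit, > 20000 nM, so its true value is not known beyond that ceiling (the limit of > 20000 nM in this assay, at which 1 of the 3 values shown sits). Compound 3 therefore sits at the weak end of the values shown.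

Compound 4, `O=c1[nH]cc(S(=O)(=O)Nc2ccccc2-c2cn(-c3ccccc3Cl)nn2)c(=O)[nH]1`, is not yet measured. It differs from compound 3 in one place: 2-chlorophenyl in place of 3-fluorophenyl on an aromatic nitrogen. Among the compounds with values here, the steps that bear on it are a 7.0-fold higher number from compound 1 to compound 2 (0.84 log units; beyond the scatter), an at least 9.1-fold higher number from compound 1 to compound 3 (0.96 log units; beyond the scatter) and an at least 1.3-fold higher number from compound 2 to compound 3 (0.11 log units; that floor lies within the scatter). Moving the substituent back to the same position as in compound 2 suggests a number near that of compound 2, which would make the expected step of an at least 1.6-fold lower number from compound 3 to compound 4 (0.22 log units; that floor lies within the scatter). For compound 4 the estimate in this assay is 12000 nM, with a range from 4000 nM to 30000 nM.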

Compound 4, half-maximal inhibitory concentration: 3170 nM
The estimate for compound 4 lay 3.8-fold (0.58 log units) above the measured number; measured number below the stated range.
By their numbers in this assay, from the lowest: compounds 1 and 4 (each within the scatter of the next); then compound 2. At a limit, above all of these: compound 3.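

In this assay, putting chloro in place of fluoro on the same aromatic carbon gives a 4.8-fold lower number from compound 2 to compound 4 (0.68 log units; beyond the scatter), so the kind of halogen matters here, and not only where it sits on the ring. The step from 4-methylphenyl to 2-chlorophenyl is a 1.4-fold higher number from compound 1 to compound 4 (0.16 log units; within the scatter), which is within the scatter, so these two different aryl groups cannot be told apart in this assay. Against 3-fluorophenyl the change gives an at least 6.3-fold lower number from compound 3 to compound 4 (0.79 log units; beyond the scatter), and this is only a floor, since compound 3 has a limit and not a number: the limit of > 20000 nM in this assay, at which 1 of the 4 values shown sits.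

The compounds shown leave open how 2-bromophenyl or 2-methylphenyl would compare with 2-chlorophenyl, and whether 3-chlorophenyl would follow 3-fluorophenyl. They also leave open what an aryl group carrying an amine or a carboxylic acid would do at this nitrogen.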